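Acetyl for methyl on the urea aryl ring

This account rests on a few compounds, and the source may have more. Where it says the series, first, only, none or still open, it means among the compounds named here.

Measured so far:
compound 1, `Cc1ccccc1NC(=O)N[C@H](C)c1ccccc1`: 100%
compound 2, `Cc1ccccc1NC(=O)N[C@@H](C)c1ccccc1`: 100%
compound 3, `C[C@H](NC(=O)Nc1ccc(C(F)(F)F)cc1)c1ccccc1`: 94%

All three numbers come from an ADME assay on the whole organism with Oryza sativa as the target, tested at 0.1 uM (on this read-out lower numbers stand for a stronger effect and higher numbers for a weaker effect at the one concentration tested), where compound 1 gives 100%. Compound 1 stands level with compound 2, the pair together the highest of the three numbers, and the number of compound 3 lies within the scatter of both. Among the compounds with values here, the only step of a single change runs no change at the digits printed from compound 1 to compound 2 (within the scatter); it is a bare inversion of configuration, which is what the fact that compounds 1 and 2 differ only in the configuration as drawn shows, so it says nothing about substituents on the aromatic ring.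

Compound 4, `CC(=O)c1ccccc1NC(=O)N[C@H](C)c1ccccc1`, is not yet measured in this assay. It differs from compound 1 by acetyl in place of methyl on an aromatic carbon. Within the data shown here, no measured step touches this position, and the values of compound 3 against compound 1 show only that a different group on the aryl ring left the number within the scatter. Hence no step beyond the scatter is expected, and the step from compound 1 to compound 4 is estimated as a number 5 percentage points lower from compound 1 to compound 4 (within the scatter). For compound 4 the expected value in this assay is 95%, between 78% and 100%.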

Compound 4, a percentage reported as activity, at one concentration (the size of the read-out at that concentration, not a potency): 96%
Compound 4: the middle estimate sits 1 percentage points below what was measured; the measured number falls inside the stated range.
By their numbers in this assay, from the lowest: compounds 3, 4, 1 and 2 (each within the scatter of the next).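

In this assay, within the data shown here, the exchange of methyl for acetyl on the aromatic carbon ortho to a large group reads as a number 4 percentage points lower from compound 1 to compound 4 (within the scatter) and is the first single change that touches a substituent on the aromatic ring, since the only earlier step was a bare inversion of configuration. At this place, then, a group of 3 heavy atoms that brings a double bond outside the aromatic rings and 1 hydrogen-bond acceptor can stand in for a group of 1 heavy atom while the number stays within the scatter of compound 1. No fact at hand bears on the origin of this result.

Still open, from the compounds shown here alone, is whether this position tolerates every group, as an amine, a carboxylic acid or a longer acyl chain on the same aromatic carbon could yet move the number beyond the scatter. Also open is whether acetyl reads the same with the opposite configuration at the saturated chain carbon, and what any of these compounds would do at another concentration.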